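The source may hold more compounds than are shown below. What is called first, only, known or untested is meant among the compounds shown, and "the series" means these compounds.

Of the compounds shown here, three built on a shared core have been measured in a functional assay on MCF7 cells (Homo sapiens) for inhibition, read by MTT assay, with a stated time of 48 h; a higher number here means a weaker inhibitor of growth, a lower number a stronger inhibitor of growth. Compound 1 `Cn1cc(C2CC(c3ccccc3)=NN2C(=O)c2cccnc2)c2ccccc21` gives 7200 nM, compound 2 `COc1ccc(C2=NN(C(=O)c3cccnc3)C(c3cn(C)c4ccc(Br)cc34)C2)cc1` gives 1560 nM, and compound 3 `COc1ccc2c(c1)c(C1CC(c3ccc(F)cc3)=NN1C(=O)c1ccc(OC)nc1)cn2C` gives 480 nM. Compound 3 is therefore the strongest inhibitor of growth of the three, and its gap to each of the other two lies beyond the usual scatter of repeated measurements.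

The unmeasured compound 4 `COc1ccc(C2=NN(C(=O)c3ccc(OC)nc3)C(c3cn(C)c4ccc(OC)cc34)C2)cc1` differs from compound 3 in one place: methoxy in place of fluoro on an aromatic carbon. Methoxy stands in place of fluoro on an aromatic carbon, para to a large group, so that 4-fluorophenyl becomes 4-methoxyphenyl.

Among the measured compounds shown here, no two measured compounds differ in only one place, so the data offer no direct guide to this swap. Compound 2 does carry the 4-methoxyphenyl group and gives 1560 nM, but it also differs from compound 3 elsewhere, so that value cannot be assigned to the group alone. With so little evidence, the expectation is a slight weakening at most, with no change beyond the scatter. The estimated step is a 1.3-fold higher number from compound 3 to compound 4 (0.10 log units; within the scatter). For compound 4 the expected value is 600 nM, with an estimated range of 200 nM to 1700 nM.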

Compound 4, concentration for 50% growth inhibition: 560 nM
Estimate against measurement, compound 4: 1.1-fold (0.03 log units) above; the measured number falls inside the stated range.
By their numbers in this assay, from the lowest: compounds 3 and 4 (each within the scatter of the next); then compound 2; then compound 1.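

In this assay the change from 4-fluorophenyl to 4-methoxyphenyl gives a 1.2-fold higher number from compound 3 to compound 4 (0.07 log units; within the scatter) and stays within the scatter, so the two compounds cannot be told apart in this assay. Among the compounds shown here, this is the first pair in the set that differs in only one place. It shows that, with the rest of compound 3 left as it stands, this aromatic carbon, para to a large group, can carry methoxy in place of fluoro without a readable difference in growth inhibition, even though methoxy brings more heavy atoms and a hydrogen-bond acceptor where fluoro counts none. No measurement is available that could explain why the two groups read alike here.

A single pair cannot show how much this position will accept: an amine such as dimethylamino, a carboxylic acid or a longer chain such as butoxy in the same place could give a very different number. It also leaves open whether the same swap would read alike in compounds carrying other groups elsewhere on the shared core, such as compound 1 or compound 2.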